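A few compounds are considered here, and "the series" means these few. Any claim that something is new, unique, unknown or untested is made for them only; others in the source may bear on it.

Compound 3, `c1ccc(-c2ccc3c(NCCCNCc4ccco4)ccnc3c2)cc1`, carries a phenyl group on the shared core. In an ADME assay for permeability, using PAMPA, with a stated time of 30 min, at pH 7.4 (on this read-out lower numbers stand for lower permeability and higher numbers for higher permeability), compound 3 gives 237 10^-6 cm/s, which places it second highest among the three measured compounds. The closest neighbour is compound 1, `COc1ccc(Oc2ccc3c(NCCCNCc4cc(F)ccc4OC)ccnc3c2)cc1`, which in this assay gives 317 10^-6 cm/s, within the scatter of compound 3. Furthest away is compound 2, `COc1ccc(F)cc1CNCCCNc1ccnc2cc(Cc3cc(C)cc(C)c3)ccc12`, which gives 23 10^-6 cm/s in this assay, a gap beyond the scatter.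

Compound 4, `CC(C)CCc1ccc2c(NCCCNCc3ccco3)ccnc2c1`, differs from compound 3 in one place: isopentyl in place of phenyl on an aromatic carbon. Within the data shown here, the only measured step available is a 14-fold lower number from compound 1 to compound 2 (1.14 log units; beyond the scatter), where a 3,5-dimethylbenzyl replaced a 4-methoxyphenoxy on an aromatic carbon. That change bears only loosely on the present one, since both of its groups are aromatic, whereas here an aromatic phenyl gives way to an isopentyl chain. With no closer comparison, a step no larger than the scatter, or a modest drop, is expected.

For compound 4 the expected number in this assay is 180 10^-6 cm/s, with a range from 60 10^-6 cm/s to 400 10^-6 cm/s, a change of a 1.3-fold lower number from compound 3 to compound 4 (0.12 log units; within the scatter).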

Compound 4, apparent permeability: 23 10^-6 cm/s
Beside the measured number, compound 4's estimate is 7.8-fold (0.89 log units) above it, and the stated range ends above it.
By their numbers in this assay, from the lowest: compounds 2 and 4 (each within the scatter of the next); then compounds 3 and 1 (each within the scatter of the next).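

In this assay, replacing phenyl with isopentyl on this aromatic carbon gives a 10-fold lower number from compound 3 to compound 4 (1.01 log units; beyond the scatter), so this position responds strongly when a six-membered aromatic ring of carbon only gives way to a chain with no ring. The earlier step, a 14-fold lower number from compound 1 to compound 2 (1.14 log units; beyond the scatter), involved two groups that each contain an aromatic ring; together, the two steps show that a large change at this carbon can occur whether or not the incoming group has a ring, in two compounds pairs that differ elsewhere in the molecule. Phenyl and isopentyl both have no hydrogen-bond donors, no hydrogen-bond acceptors and no net charge, so those counts do not separate them, and no measurement shown here gives a reason for the step. From the compounds shown here alone, it remains open whether the loss of the ring or some other difference between the two groups matters most, which a cyclohexyl group at the same carbon could help to separate. A shorter chain such as ethyl, or an amine at this carbon, would show how far the result extends beyond this single pair.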